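Trimming the Aryloxy Arm to a Methoxy Group

The source may report more compounds than this note shows. Statements on the series, on what has been measured and on what is new or still open speak of the compounds shown alone.

Compound 1, `O=C(Nc1cccc(Oc2ccccn2)c1)C1CCCN(C(=O)c2cc(C(F)(F)F)cc(C(F)(F)F)c2)C1`, was tested in an ADME assay on PC-3 cells (Homo sapiens) for cytotoxicity, read by WST assay, tested at 100 uM (a lower number here means less inhibition, a higher number more inhibition at the concentration tested (going by the name of the read-out)), where compound 1 gives 0%. Compound 2, `O=C(Nc1cccc(Oc2nccc(C(F)(F)F)c2Cl)c1)C1CCCN(C(=O)c2cc(C(F)(F)F)cc(C(F)(F)F)c2)C1`, carries 3-chloro-4-(trifluoromethyl)pyridin-2-yl in place of pyridin-2-yl on an oxygen on an aromatic ring, and in this assay compound 2 gives 0%. The step of no change at the digits printed from compound 1 to compound 2 (within the scatter) shows that swapping the ring on that oxygen left the read-out untouched, so compound 2 stands level with compound 1, with both compounds showing no measurable inhibition of cell growth.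

Compound 3, `COc1cccc(NC(=O)C2CCCN(C(=O)c3cc(C(F)(F)F)cc(C(F)(F)F)c3)C2)c1`, has not been measured yet. It differs from compound 2 at the same oxygen: methyl in place of 3-chloro-4-(trifluoromethyl)pyridin-2-yl on an oxygen on an aromatic ring. For the measured compounds named here, the only measured step that bears on this position, from compound 1 to compound 2, was flat within the scatter, and nothing in the two values suggests that this part of the molecule drives the read-out. The step of a number 2 percentage points higher from compound 2 to compound 3 (within the scatter) is therefore expected to stay within the scatter. For compound 3 the estimated value in this assay is 2%, with a range from -10% to 15%.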

Compound 3, a percentage reported as inhibition, at one concentration (the size of the read-out at that concentration, not a potency): 0%
Compound 3: the middle estimate sits 2 percentage points above what was measured; measured number inside the range.
By their numbers in this assay, from the lowest: compounds 1, 2 and 3 (each within the scatter of the next).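

In this assay the read-out shows no change at the digits printed from compound 2 to compound 3 (within the scatter) when methyl replaces 3-chloro-4-(trifluoromethyl)pyridin-2-yl on the oxygen. This is a much larger structural cut than the earlier swap between two aromatic rings, since a group of 11 heavy atoms with a six-membered aromatic ring gives way to 1 heavy atom and no ring. The smaller pyridin-2-yl group tells the same story, with no change at the digits printed from compound 1 to compound 3 (within the scatter), so among these three compounds an aromatic ring on this oxygen is not needed to keep the read-out where it stands, and no information here explains why the position is so silent.

Going by these compounds, whether an amine, a carboxylic acid or a longer chain on this oxygen would move the read-out stays open, since all three groups seen so far leave it in the same place. Also open, on these data alone, is whether changes elsewhere on the shared core would do so, and what these compounds do at concentrations other than the single one tested in this assay.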